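This account rests on a few compounds, and the source may have more. Where it says the series, first, only, none or still open, it means among the compounds named here.

Measured in a physicochemical assay for lipophilicity, at pH 7.4; a lower number here means a more polar compound, a higher number a more lipophilic compound:
Compound 1 `CNC(=O)c1cc(C(=O)N[C@H]2[C@@H]3C[C@H](O)C[C@@H]32)cc2c1OC[C@@]2(C)c1ccccc1`: 3.7
Compound 2 `CNC(=O)c1cc(C(=O)N[C@H]2[C@@H]3C[C@@H](O)C[C@@H]32)cc2c1OC[C@H]2c1ccccc1`: 2.9

Compound 1 stands higher of the two on this scale, and compound 2 lies below it by a gap beyond the usual scatter of such measurements. Compound 3 `CNC(=O)c1cc(C(=O)N[C@H]2CC[C@H](O)CC2)cc2c1OC[C@@]2(C)c1ccccc1` has not yet been measured. It keeps the core of compound 1 and differs only in the group on the amide-type nitrogen, where a 4-hydroxycyclohexyl group takes the place of the fused ring group: a group of 7 heavy atoms (6 carbon, 1 oxygen; one six-membered non-aromatic ring of carbon only) in place of a group of 7 heavy atoms (6 carbon, 1 oxygen; one three-membered non-aromatic ring of carbon only, one five-membered non-aromatic ring of carbon only), on an amide-type nitrogen. Going by the values given here, no measured pair shows a change of this kind, so the expectation rests on the structural change and on compound 1 at 3.7, and no step beyond the scatter is expected in this assay. The estimated step is a number 0.10 log units lower from compound 1 to compound 3 (within the scatter). For compound 3 the expected value is 3.6, with an estimated range from 3.2 to 4.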

Compound 3, distribution coefficient: 3.3
For compound 3 the middle estimate is 0.30 log units above the measured one; the measured number falls inside the stated range.
By their numbers in this assay, from the lowest: compound 2; then compound 3; then compound 1.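

Going by these compounds alone, at the amide-type nitrogen, with the core of compound 1 kept, putting 4-hydroxycyclohexyl in place of the fused ring group gives a number 0.40 log units lower from compound 1 to compound 3 (beyond the scatter) in this assay and is the first single-place step seen at this position. The two groups match in their counts of heavy atoms, hydrogen-bond donors and acceptors, so the step comes with a difference in ring make-up and in defined stereocentres, not with a difference in those counts. No supporting measurement bears on why the number moves.

The compounds shown do not separate the ring change from the stereocentre change, and they leave open whether the step would recur on another core. They also leave open how this position would respond to a 4-aminocyclohexyl or 4-carboxycyclohexyl group.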